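A few compounds are considered here, and "the series" means these few. Any claim that something is new, unique, unknown or untested is made for them only; others in the source may bear on it.

For the measured compounds named here, in an ADME assay on HEK293 cells (Homo sapiens) for cytotoxicity, read by MTT assay, with a stated time of 72 h (a higher number here means a weaker inhibitor, a lower number a stronger inhibitor), compound 2 `O=C(CN1CCN(C(=O)c2ccc(Br)cc2)CC1)N1CCN(CCCc2c[nH]c3ccc(F)cc23)CC1` gives 60500 nM, the lower of the two numbers so far, and compound 1 `O=C(CN1CCN(C(=O)c2ccccc2)CC1)N1CCN(CCCc2c[nH]c3ccc(F)cc23)CC1` gives 148000 nM. The next change leads to compound 3 `Cc1ccc(C(=O)N2CCN(CC(=O)N3CCN(CCCc4c[nH]c5ccc(F)cc45)CC3)CC2)cc1`: methyl in place of bromo on an aromatic carbon, para to a large group. Going by the values given here, one measured step bears on it: a 2.4-fold lower number from compound 1 to compound 2 (0.39 log units; beyond the scatter), a modest step beyond the scatter, for bromo in place of hydrogen on an aromatic carbon. Among the compounds with values here, no measured compound carries methyl, so this rests on that single step. A small move back towards the number of compound 1 is expected in this assay, perhaps not exceeding the scatter. The expected step runs a 1.5-fold higher number from compound 2 to compound 3 (0.17 log units; within the scatter). For compound 3 the estimated value is 90000 nM, with an expected range of 50000 nM to 160000 nM.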

Compound 3, half-maximal inhibitory concentration: 141000 nM
Estimate against measurement, compound 3: 1.6-fold (0.19 log units) below, and the stated range covers the measured number.
By their numbers in this assay, from the lowest: compound 2; then compounds 3 and 1 (each within the scatter of the next).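

In this assay, methyl at this position, para to a large group, does not keep what bromo gave: the step runs a 2.3-fold higher number from compound 2 to compound 3 (0.37 log units; beyond the scatter), beyond the scatter. Set against the unsubstituted benzoyl compound, methyl leaves the number in place, at a 1.0-fold lower number from compound 1 to compound 3 (0.02 log units; within the scatter), so compound 1 and compound 3 cannot be told apart and the lower number of compound 2 goes with bromo, not with just any group at this position. No measurement on these compounds accounts for the difference between bromo and methyl.

Going by these compounds, whether the lower number is particular to bromo remains open, and chloro, iodo or trifluoromethyl at the same position would test this. Also open, on these data alone, is whether methoxy here would stay with methyl or move towards bromo.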